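A few compounds are considered here, and "the series" means these few. Any claim that something is new, unique, unknown or untested is made for them only; others in the source may bear on it.

Compound 1 `Cc1ccc(S(=O)(=O)c2cnc3cc(F)ccc3c2-c2ccc(F)cc2)cc1C` is examined in an ADME assay on microsomes from liver (Homo sapiens) for metabolic stability, tested at 2.5 uM (a lower number here means slower removal, a higher number faster removal of the compound), where compound 1 gives 9.25 mL/min. Among the three measured compounds this is the highest number. Compound 2 `Cc1ccc(S(=O)(=O)c2cnc3cc(F)ccc3c2-c2ccc(Cl)cc2)cc1C` gives 7.88 mL/min, and the step of a 1.2-fold lower number from compound 1 to compound 2 (0.07 log units; within the scatter) lies within the scatter. Compound 3 `Cc1ccc(S(=O)(=O)c2cnc3cc(F)ccc3c2-c2cccc(F)c2)cc1C` gives 3.71 mL/min; the step of a 2.5-fold lower number from compound 1 to compound 3 (0.40 log units; beyond the scatter) is beyond the scatter, as is the step of a 2.1-fold lower number from compound 2 to compound 3 (0.33 log units; beyond the scatter). The unmeasured compound 4 `COc1ccc(S(=O)(=O)c2cnc3cc(F)ccc3c2-c2ccc(F)cc2)cc1` differs from compound 1 in a single place: 4-methoxyphenyl in place of 3,4-dimethylphenyl on a sulfonyl sulfur. None of the three measured steps touches the group on the sulfonyl sulfur; each of them alters the other aromatic ring attached to the core of compound 1. Going by the values given here, the data therefore hold no step that bears directly on this change, and the measured steps only show how far the numbers spread across this small set. Compound 4 is therefore expected to give 8 mL/min, with a range from 4 mL/min to 16 mL/min. The expected step of a 1.2-fold lower number from compound 1 to compound 4 (0.06 log units; within the scatter) would stay within the scatter.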

Compound 4, intrinsic clearance in a liver preparation (reported as CLH), per the amount of preparation that the assay uses: 1.71 mL/min
The estimate for compound 4 lay 4.7-fold (0.67 log units) above the measured number, outside the stated range (below it).
By their numbers in this assay, from the lowest: compound 4; then compound 3; then compounds 2 and 1 (each within the scatter of the next).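

Going by these compounds alone, putting 4-methoxyphenyl in place of 3,4-dimethylphenyl on a sulfonyl sulfur gives a 5.4-fold lower number from compound 1 to compound 4 (0.73 log units; beyond the scatter) in this assay and so shows that this position, untouched by the earlier steps, also moves the number. This step exceeds a 2.5-fold lower number from compound 1 to compound 3 (0.40 log units; beyond the scatter) on the other aromatic ring, and it leaves the count of 8 heavy atoms unchanged, with the entering group holding 1 hydrogen-bond acceptor where the leaving group holds 0. Nothing at hand explains the step.

The compounds shown do not tell whether the lower number goes with the methoxy group or with the loss of the methyl groups, a question on which a 4-methylphenyl group at this position would bear. They also leave open how a 4-aminophenyl or 4-carboxyphenyl group would fare there, and whether the step would hold with the 3-fluorophenyl group of compound 3 in place.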